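This account rests on a few compounds, and the source may have more. Where it says the series, first, only, none or still open, it means among the compounds named here.

Measured so far in a functional assay, read by spectrophotometry (on this read-out higher numbers stand for an effect only at larger amounts of compound and lower numbers for an effect already at smaller amounts), so far:
Compound 1 `COc1ccc(-c2cc(=O)c3ccc(O)cc3o2)cc1OC` gives 22.4 nM
Compound 2 `COc1ccc(-c2cc(=O)c3ccc(OCCCN4CCC(C)CC4)cc3o2)cc1` gives 26.6 nM

In this assay compound 2 stands level with compound 1, since their two values lie within the usual scatter. Compound 3 `COc1ccc(-c2cc(=O)c3ccc(OCCCN4CCC(C)CC4)cc3o2)cc1OC` differs from compound 2 by one change, (methoxy in place of hydrogen on an aromatic carbon), methoxy in place of hydrogen on an aromatic carbon, which turns 4-methoxyphenyl to 3,4-dimethoxyphenyl. Going by the values given here, no measured pair shows this change alone. Compound 1 carries 3,4-dimethoxyphenyl and compound 2 carries 4-methoxyphenyl, but they also differ elsewhere. No shift beyond the scatter is expected in this assay, and the estimate is a 1.1-fold lower number from compound 2 to compound 3 (0.03 log units; within the scatter) with no clear direction. Compound 3 is expected at 25 nM within an estimated range of 8 nM to 80 nM in this measurement.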

Compound 3, half-maximal effective concentration: 24.1 nM
Beside the measured number, compound 3's estimate is 1.0-fold (0.02 log units) above it, and the stated range covers the measured number.
By their numbers in this assay, from the lowest: compounds 1, 3 and 2 (each within the scatter of the next).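

In this assay, going by these compounds alone, methoxy in place of hydrogen, ortho to a methoxy group, gives a 1.1-fold lower number from compound 2 to compound 3 (0.04 log units; within the scatter), the first reading of this change alone. Within the data shown here, the 3-(4-methylpiperidin-1-yl)propyl group in place of hydrogen on the oxygen, also read alone for the first time, gives a 1.1-fold higher number from compound 1 to compound 3 (0.03 log units; within the scatter), so neither change separates the compounds. No measured information accounts for these results. Still open, from the compounds shown here alone, is whether an ethoxy or a hydroxyl at this ring position would give a step beyond the scatter. The same question applies to a morpholine in place of the 4-methylpiperidine.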